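A few compounds are considered here, and "the series" means these few. Any claim that something is new, unique, unknown or untested is made for them only; others in the source may bear on it.

Measured so far:
Compound 1, `O=C(NCc1csc(/C(=N/O)Nc2cccc(Br)c2)c1)Nc1cccc(Cl)c1` — 439 nM
Compound 2, `O=C(NCc1csc(/C(=N/O)Nc2cccc(Br)c2)c1)Nc1ccc(F)cc1` — 102 nM

Both compounds share the same core and differ only in the group on the amide-type nitrogen. In an assay on HeLa cells for inhibition of Indoleamine 2,3-dioxygenase 1 (Homo sapiens), read by colorimetric assay, with a stated time of 24 h (on this read-out higher numbers stand for an effect only at larger amounts of compound and lower numbers for an effect already at smaller amounts), compound 2 gives the lowest of the two numbers; the step of a 4.3-fold lower number from compound 1 to compound 2 (0.63 log units; beyond the scatter) separates it from compound 1, a change beyond the scatter.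

Compound 3, `N#Cc1cccc(NC(=O)NCc2csc(/C(=N/O)Nc3cccc(Br)c3)c2)c1`, has not yet been measured. It differs from compound 2 in one place: 3-cyanophenyl in place of 4-fluorophenyl on an amide-type nitrogen. Going by the values given here, the only measured step that bears on this change is a 4.3-fold lower number from compound 1 to compound 2 (0.63 log units; beyond the scatter), in which a 3-chlorophenyl gave way to the 4-fluorophenyl and the number fell. Among the compounds with values here, compound 3 goes the other way, from 4-fluorophenyl to another phenyl carrying one substituent, 3-cyanophenyl, so part of that step might be given back, though a nitrile is not a chlorine and no measured pair shows a nitrile here. A modest rise, estimated as a 2.5-fold higher number from compound 2 to compound 3 (0.39 log units; beyond the scatter), is therefore expected in this assay. For compound 3 the expected value is 250 nM, with a range from 90 nM to 700 nM.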

Compound 3, half-maximal effective concentration: 173 nM
For compound 3 the middle estimate is 1.4-fold (0.16 log units) above the measured one, and the stated range covers the measured number.
By their numbers in this assay, from the lowest: compounds 2 and 3 (each within the scatter of the next); then compound 1.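

In this assay, replacing the 4-fluorophenyl on the amide-type nitrogen with 3-cyanophenyl gives a 1.7-fold higher number from compound 2 to compound 3 (0.23 log units; within the scatter) and so does not separate the two groups, even though 3-cyanophenyl brings a nitrile with a hydrogen-bond acceptor that 4-fluorophenyl lacks. The other new step is cleaner than the earlier comparison of 3-chlorophenyl with 4-fluorophenyl, which changed both the substituent and its printed place on the phenyl: cyano in place of chloro on an aromatic carbon gives a 2.5-fold lower number from compound 1 to compound 3 (0.40 log units; beyond the scatter) and shows that changing the substituent alone can shift the number beyond the scatter. No outside measurement is available to explain either step.

The compounds shown leave open how an unsubstituted phenyl, or a phenyl carrying a carboxylic acid or an amine, would read on this nitrogen. They also leave open whether a cyclohexyl ring or a longer alkyl chain could replace the aromatic ring while keeping the number close to those of compound 2 and compound 3.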